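A few compounds are considered here, and "the series" means these few. Any claim that something is new, unique, unknown or untested is made for them only; others in the source may bear on it.

Of the compounds shown here, two have so far been measured in a functional assay on microsomes from aorta for inhibition of Thromboxane-A synthase (Homo sapiens), in the presence of a further agent that is not named here; on this read-out lower numbers stand for stronger inhibition and higher numbers for weaker inhibition. Compound 1 `Cn1cc(/C=C/C(=O)O)cc1Cn1ccnc1` gives 4600 nM. Compound 2 `CCn1c(/C=C(/C)C(=O)O)ccc1Cc1cccnc1` gives 42 nM, the lowest of the two numbers, and its gap to compound 1 lies far beyond the usual scatter of repeated measurements. Compound 3 `C/C(=C/c1ccc(Cc2cccnc2)n1CC(C)(C)C)C(=O)O` has not yet been measured. It differs from compound 2 in a single place: tert-butyl in place of methyl on a saturated chain carbon bound to an aromatic nitrogen. Within the data shown here, no measured pair shows this same change, so there is no direct guide to what it does. The expected step in this assay is a 1.5-fold higher number from compound 2 to compound 3 (0.19 log units; within the scatter), a modest move toward a slightly higher number that may well fall inside the scatter. Compound 3 is therefore estimated at 65 nM, with a likely range from 15 nM to 280 nM, which would keep it far closer to compound 2 than to compound 1.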

Compound 3, half-maximal inhibitory concentration: 78000 nM
Compound 3: the middle estimate sits 1200-fold (3.08 log units) below what was measured; measured number above the stated range.
By their numbers in this assay, from the lowest: compound 2; then compound 1; then compound 3.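

In this assay the change from methyl to tert-butyl on a saturated chain carbon bound to an aromatic nitrogen gives a 1900-fold higher number from compound 2 to compound 3 (3.27 log units; beyond the scatter) and so shows that this place is far from indifferent to what it carries. Read one bond further out, ethyl becomes neopentyl: only carbon enters, with no ring, no hydrogen-bond donor or acceptor and no net charge, yet that change alone moves the number this far. Nothing shown here explains the loss.

The compounds shown leave open whether the number climbs gradually or abruptly between ethyl and neopentyl, which a propyl or isobutyl chain at this place could help to settle. Also open, as far as these compounds go, is how a longer chain ending in an amine or a carboxylic acid would fare here.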